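Trimethoxyphenyl Replaces Hydroxy-Methoxyphenyl in a Chalcone Series

This account rests on a few compounds, and the source may have more. Where it says the series, first, only, none or still open, it means among the compounds named here.

Measured so far:
compound 1 `COc1cc(/C=C/C(=O)c2cccc(-n3cc(-c4ccc(Cl)cc4)[nH]c3=O)c2)cc(OC)c1OC` — 30200 nM
compound 2 `COc1ccc(-c2cn(-c3cccc(C(=O)/C=C/c4ccc(O)c(OC)c4)c3)c(=O)[nH]2)cc1` — 3720 nM

Of the compounds shown here, two from this study have been tested in a functional assay on A498 cells (Homo sapiens) for inhibition; a lower number here means a stronger inhibitor of growth, a higher number a weaker inhibitor of growth. Compound 1 gives 30200 nM in this assay, while compound 2 gives 3720 nM. Compound 2 therefore stands at the lower of the two numbers, and the gap to compound 1 lies beyond the usual scatter, so compound 2 is the stronger growth inhibitor of the pair.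

The next compound, compound 3 `COc1ccc(-c2cn(-c3cccc(C(=O)/C=C/c4cc(OC)c(OC)c(OC)c4)c3)c(=O)[nH]2)cc1`, keeps the core of compound 2 and changes one group: 3,4,5-trimethoxyphenyl in place of 4-hydroxy-3-methoxyphenyl on a double-bonded chain carbon bound to a double-bonded chain carbon. The structures of compound 1 and compound 2 differ in more than one place, so no single step can be read from them. Among the measured compounds shown here, still, the only measured compound carrying the 3,4,5-trimethoxyphenyl group, compound 1, shows the higher number, and the 4-hydroxy-3-methoxyphenyl group sits on the compound with the lower number. On that thin basis, a move toward a weaker inhibitor is expected from compound 2 to compound 3, with an expected step of a 2.7-fold higher number from compound 2 to compound 3 (0.43 log units; beyond the scatter) in this assay. Compound 3 is estimated at 10000 nM, within a range of 3000 nM to 35000 nM.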

Compound 3, concentration for 50% growth inhibition: 4210 nM
Compound 3: middle estimate off by 2.4-fold (0.38 log units), on the high side; the measured number falls inside the stated range.
By their numbers in this assay, from the lowest: compounds 2 and 3 (each within the scatter of the next); then compound 1.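

In this assay, 3,4,5-trimethoxyphenyl in place of 4-hydroxy-3-methoxyphenyl on a double-bonded chain carbon bound to a double-bonded chain carbon gives a 1.1-fold higher number from compound 2 to compound 3 (0.05 log units; within the scatter), so this swap, which goes from 1 hydrogen-bond donor to 0, leaves no readable mark on growth inhibition at this position. Among the compounds shown here, with the trimethoxyphenyl group now held fixed, the change elsewhere can be read for the first time: methoxy in place of chloro on an aromatic carbon gives a 7.2-fold lower number from compound 1 to compound 3 (0.86 log units; beyond the scatter), which places the high number of compound 1 with its chloro group and not with its trimethoxyphenyl group. Nothing measured here says why either step comes out as it does.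

The compounds shown leave open whether the chain position would stay this tolerant of a different group, such as an amine, a carboxylic acid or a phenyl ring with no oxygen groups at all. They also leave open how a fluoro or a hydrogen would compare with chloro and methoxy on the aromatic carbon, and whether the chloro effect would hold alongside 4-hydroxy-3-methoxyphenyl.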